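From a Fluorophenoxy to a Phenylsulfonyl Side Group

The source may report more compounds than this note shows. Statements on the series, on what has been measured and on what is new or still open speak of the compounds shown alone.

Of the compounds shown here, two sharing one core have been measured in a functional assay for inhibition, with Homo sapiens as the target; on this read-out lower numbers stand for tighter binding and higher numbers for weaker binding. Compound 1 `O=C(O)CC/C=C\CC1COC(c2ccc([N+](=O)[O-])cc2)OC1c1cccnc1` gives 933 nM. Compound 2 `CC(C)(Oc1ccc(F)cc1)C1OCC(C/C=C\CCC(=O)O)C(c2cccnc2)O1` gives 120 nM, the lower of the two numbers, and its gap to compound 1 lies beyond the usual scatter of this assay, so compound 2 stands as the tighter binder of the pair.

Compound 3 `CC(C)(C1OCC(C/C=C\CCC(=O)O)C(c2cccnc2)O1)S(=O)(=O)c1ccccc1` has not yet been tested. It differs from compound 2 in a single place: phenylsulfonyl in place of 4-fluorophenoxy on a saturated chain carbon bound to two saturated chain carbons and a saturated ring carbon. Going by the values given here, no measured pair here isolates such a swap, so nothing in the data says how large the effect should be. A moderate loss of tightness is expected, and the step of a 2.1-fold higher number from compound 2 to compound 3 (0.32 log units; beyond the scatter) is the estimate of that change in this assay. For compound 3 the estimated value in this assay is 250 nM, with a range from 60 nM to 1000 nM.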

Compound 3, dissociation constant: 3160 nM
For compound 3 the middle estimate is 13-fold (1.10 log units) below the measured one; measured number outside the range, above it.
By their numbers in this assay, from the lowest: compound 2; then compound 1; then compound 3.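

This saturated chain carbon, bound to two saturated chain carbons and a saturated ring carbon, is sensitive to what it carries: in this assay, placing phenylsulfonyl where 4-fluorophenoxy stood gives a 26-fold higher number from compound 2 to compound 3 (1.42 log units; beyond the scatter) and makes this a large change. Both groups hold one six-membered aromatic ring of carbon only and are close in heavy-atom count, so keeping an aromatic ring here is not enough to keep the number low. Nothing available explains this weaker binding, so its cause remains unknown.

The swap changes both the link to the ring and the fluorine, so the two effects cannot be told apart. A plain phenoxy group and a 4-fluorophenylsulfonyl group at this position would show which change matters more.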